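The compounds below may be only part of what the source reports. "The series", "measured", "known", "first", "only" and "open" are said of these compounds alone.

Of the compounds shown here, three built on one shared core have been tested in a functional assay on A-375 cells (Homo sapiens) for activation, with a stated time of 3 days; on this read-out lower numbers stand for an effect already at smaller amounts and higher numbers for an effect only at larger amounts of compound. Compound 1 `O=C(Nc1ccc(-c2ccccc2)cc1)C1CCCN(Cc2ccc(F)c(F)c2)C1` gives 5000 nM, compound 2 `O=C(Nc1ccc(-c2ccncc2)cc1)C1CCCN(Cc2ccc(F)c(F)c2)C1` gives 1180 nM, and compound 3 `O=C(Nc1ccc(-c2ncc[nH]2)cc1)C1CCCN(Cc2ccc(F)c(F)c2)C1` gives 8000 nM. Compound 3 stands at the top end of these three numbers, but the step from compound 1 is small, a 1.6-fold higher number from compound 1 to compound 3 (0.20 log units; within the scatter), and lies within the usual scatter, so compound 1 and compound 3 cannot be told apart. The step from compound 2 is clearer: a 6.8-fold higher number from compound 2 to compound 3 (0.83 log units; beyond the scatter). Compound 4 `O=C(Nc1ccc(-c2ccoc2)cc1)C1CCCN(Cc2ccc(F)c(F)c2)C1` differs from compound 3 in one place: furan-3-yl in place of 1H-imidazol-2-yl on an aromatic carbon. The two measured steps ending at compound 3 both swap the ring on this aromatic carbon and show that such swaps move the number by a modest amount at most. The group entering in compound 4, like the phenyl of compound 1, carries no hydrogen-bond donor, and compound 1 sits below compound 3. A modest drop from compound 3 is therefore expected, a 2.0-fold lower number from compound 3 to compound 4 (0.30 log units; within the scatter). Compound 4 is estimated at 4000 nM, with a range from 1500 nM to 12000 nM.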

Compound 4, half-maximal effective concentration: 3000 nM
For compound 4 the middle estimate is 1.3-fold (0.12 log units) above the measured one; measured number inside the range.
By their numbers in this assay, from the lowest: compound 2; then compounds 4, 1 and 3 (each within the scatter of the next, the first and the last beyond it).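

The swap between two five-membered aromatic rings with 5 heavy atoms each can be read at this position: furan-3-yl, with 0 hydrogen-bond donors, and 1H-imidazol-2-yl, with 1, give numbers that lie apart (a 2.7-fold lower number from compound 3 to compound 4 (0.43 log units; beyond the scatter)), so ring size alone does not fix the number here. Furan-3-yl and phenyl cannot be told apart (a 1.7-fold lower number from compound 1 to compound 4 (0.22 log units; within the scatter)), and since compound 1 also lies within the scatter of compound 3, it cannot be separated from either of the two five-membered cases. The pyridin-4-yl of compound 2 remains clearly apart from the furan-3-yl (a 2.5-fold higher number from compound 2 to compound 4 (0.41 log units; beyond the scatter)), and compound 2 now has the lowest number, beyond the scatter of all three others.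

From the compounds shown here alone, how an amine or a carboxylic acid on this aromatic carbon would behave stays open. The data offer no measured explanation for why these rings differ.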